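The source may hold more compounds than are shown below. What is called first, only, known or untested is meant among the compounds shown, and "the series" means these compounds.

Measured in an assay on isolated protein for inhibition of protein kinase C theta type (Homo sapiens), read by TR-FRET, with a stated time of 2 h; on this read-out lower numbers stand for stronger inhibition and higher numbers for weaker inhibition:

Compound 1, `N#Cc1cnc(NCc2cnccc2C(F)(F)F)cc1NCC1CCOCC1`: 400 nM
Compound 2, `N#Cc1cnc(NCc2cncnc2-c2ccccc2)cc1N[C@H]1CC[C@@H](O)CC1`: 90 nM
Compound 3, `CC1(C)[C@@H](O)C[C@H]1Nc1nc(NCc2cnccc2C(F)(F)F)ncc1C#N`: 4 nM

Among these three, compound 3 has the lowest number in this assay. Its nearest neighbour is compound 2, and the gap between them lies beyond the usual scatter of repeated measurements; compound 1 stands furthest away, again well beyond the scatter. Compound 3 is therefore the most potent of the three measured compounds by a clear margin.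

The piece now follows the step from compound 3 to compound 4, `CC1(C)[C@H](O)C[C@@H]1Nc1nc(NCc2cnccc2C(F)(F)F)ncc1C#N`. The change is purely one of configuration: the two compounds have the same atoms and bonds and differ only in configuration as drawn: 2 of 2 stereo elements differ (all stereocentres are inverted: mirror images); a stereocentre at a saturated ring carbon is drawn S in compound 3 and R in compound 4; a stereocentre at a saturated ring carbon is drawn R in compound 3 and S in compound 4. The two compounds have the same atoms and bonds and differ only in the drawn arrangement at the two saturated ring carbons, so compound 4 is the mirror image of compound 3.

Within the data shown here, no pair of measured compounds shows such a step, so there is no directly comparable change to draw on. Mirror images of a tightly bound compound are commonly not equivalent, and the expectation here is that compound 4 gives a higher number than compound 3, a step of a 30-fold higher number from compound 3 to compound 4 (1.48 log units; beyond the scatter) in this assay, with considerable uncertainty about its size. Compound 4 is accordingly estimated at 120 nM, within a range of 12 nM to 1500 nM.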

Compound 4, half-maximal inhibitory concentration: 300 nM
For compound 4 the middle estimate is 2.5-fold (0.40 log units) below the measured one; low and high end bracket the measured number.
By their numbers in this assay, from the lowest: compound 3; then compound 2; then compounds 4 and 1 (each within the scatter of the next).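

Inverting both stereocentres at the saturated ring carbons gives a 75-fold higher number from compound 3 to compound 4 (1.88 log units; beyond the scatter) in this assay, and this is the first change in the series that can be read on its own. Among these compounds, the gaps among the earlier compounds came with differences in more than one place, so they could not be tied to any single change, and they said nothing about configuration at this position. Here the large loss can be assigned to the drawn arrangement at these two ring carbons alone, because no other change accompanies it: the fact that compounds 3 and 4 differ only in the configuration as drawn

The two stereocentres change together in this step, so it remains open whether one of them accounts for most of the step or both contribute, and the two forms with a single inverted centre are not among the compounds shown. From the compounds shown here alone, it also remains open whether the same sensitivity to configuration would hold with an amine or a methoxy group in place of the hydroxyl, and how the mirror-image pair would compare in any read-out other than this assay.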